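This account rests on a few compounds, and the source may have more. Where it says the series, first, only, none or still open, it means among the compounds named here.

Measured so far:
- compound 1 `O[C@@H]1Cc2ccccc2N[C@H](c2ccccc2)C1`: in an ADME assay on Vero cells (Chlorocebus sabaeus) for cytotoxicity, read by MTT assay, with a stated time of 72 h (a lower number here means that less compound is tolerated, a higher number that more compound is tolerated), compound 1 sits at the assay limit > 300000 nM.
- compound 2 `O[C@@H]1Cc2cc(Cl)ccc2N[C@H](c2ccccc2)C1`: in this assay compound 2 gives 191000 nM.

For the measured compounds named here, compound 2 holds the only actual number in this assay; the other value shown is a limit. Going by the values given here, the one measured step, an at least 1.5-fold lower number from compound 1 to compound 2 (0.19 log units; that floor lies within the scatter), rests on (the limit of > 300000 nM in this assay, at which 1 of the 2 values shown sits), so its size is a floor and lies within the scatter.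

Compound 3 `O[C@@H]1Cc2cc(F)ccc2N[C@H](c2ccccc2)C1` differs from compound 2 by fluoro in place of chloro on an aromatic carbon. The step from compound 1 to compound 2 brought the chloro in; the present step takes the chloro out again and puts fluoro in its place, so it is a partial reversal of that step. Since an at least 1.5-fold lower number from compound 1 to compound 2 (0.19 log units; that floor lies within the scatter) was itself within the scatter, no change beyond the scatter is expected in this assay, with the direction, if any, towards a higher number. Compound 3 is therefore estimated at 230000 nM, with a range of 110000 nM to 480000 nM. The expected step is a 1.2-fold higher number from compound 2 to compound 3 (0.08 log units; within the scatter).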

Compound 3, half-maximal cytotoxic concentration: > 300000 nM
Compound 3: only a limit was reported; the forecaster's own chance of this, stated with the estimate: 35%; middle value at least 1.3-fold (0.11 log units) away from the limit.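

In this assay, the position now carries a second halogen, and the change of chloro to fluoro gives an at least 1.5-fold higher number from compound 2 to compound 3 (0.19 log units; that floor lies within the scatter), so this change, like the earlier one, does not separate from the scatter. Compound 3 gives > 300000 nM, which is a limit and not a number. The step between compound 1 and compound 3 cannot be read, so hydrogen and fluoro cannot be told apart at this position, and the comparison of the series rests largely on one ceiling: the limit of > 300000 nM in this assay, at which 2 of the 3 values shown sit.

From the compounds shown here alone, both readable steps around compound 2 are floors within the scatter, so it remains open whether chloro truly differs from hydrogen or fluoro here. Also open, going by these compounds, is whether bromo, an amine or a carboxylic acid at this position would give a number beyond the scatter from compound 2.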